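The compounds below may be only part of what the source reports. "The series", "measured", "known", "first", "only" and "open" are said of these compounds alone.

In a functional assay on the whole organism (strain Swiss CD-1) with Mus musculus as the target, with a stated time of 2 h (a lower number here means that less compound is needed, a higher number that more compound is needed for the effect), compound 2 (`COC[C@@H](C(=O)N1CCN(c2ccc(C(F)(F)F)cc2)CC1)N1C(=O)CCC1=O`) gives 37.9 mg/kg and compound 1 (`COCC(C(=O)N1CCN(c2cccc(Cl)c2)CC1)N1C(=O)CCC1=O`) gives 26.1 mg/kg so the two sit within the usual scatter of each other. Compound 3 (`COC[C@H](C(=O)N1CCN(c2ccc(C(F)(F)F)cc2)CC1)N1C(=O)CCC1=O`) differs from compound 2 as follows: the two compounds have the same atoms and bonds and differ only in configuration as drawn: 1 of 1 stereo elements differ; a stereocentre at a saturated chain carbon is drawn S in compound 2 and R in compound 3 and a stereocentre at a saturated chain carbon is drawn S in compound 2 and R in compound 3. Among the compounds with values here, no measured pair shows what such a swap does, so no direction is favoured. The expected step of a 1.2-fold lower number from compound 2 to compound 3 (0.07 log units; within the scatter) stays within the scatter. For compound 3 the estimated value is 32 mg/kg with a likely range from 14 mg/kg to 75 mg/kg in this estimate.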

Compound 3, dose for half-maximal effect: 21.1 mg/kg
Beside the measured number, compound 3's estimate is 1.5-fold (0.18 log units) above it; the measured number falls inside the stated range.
By their numbers in this assay, from the lowest: compounds 3, 1 and 2 (each within the scatter of the next).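

Within the data shown here, this is the first pair in this assay that isolates the configuration at the saturated chain carbon, and the swap from S to R gives a 1.8-fold lower number from compound 2 to compound 3 (0.25 log units; within the scatter). That step stays within the usual scatter, so this pair gives no sign that the drawn configuration at this carbon changes the dose needed, and the comparison is a clean one: the fact that compounds 2 and 3 differ only in the configuration as drawn

Still open, as far as these compounds go, is whether the swap would have a larger effect with a carboxylic acid or a longer ether chain on this carbon. From the compounds shown here alone, it is also open whether it would act alike in compound 1, which is drawn without configuration.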